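The source may report more compounds than this note shows. Statements on the series, on what has been measured and on what is new or still open speak of the compounds shown alone.

Measured compounds: compound 1 `NCC(O)CNc1cc(N2CCc3ccccc3C2)nc2ccccc12` gives 21000 nM in an ADME assay on HEp-2 cells (Homo sapiens) for cytotoxicity, read by CCK-8 assay, with a stated time of 5 days; on this read-out higher numbers stand for lower toxicity in this test and lower numbers for higher toxicity in this test; compound 2 `NCCCNc1cc(N2CCc3ccccc3C2)nc2ccccc12` gives 8400 nM in this assay.

Within the data shown here, compound 2 holds the lowest of the two numbers, the only other being compound 1 with a step of a 2.5-fold lower number from compound 1 to compound 2 (0.40 log units; beyond the scatter). Compound 3 `N=C(N)NCCNc1cc(N2CCc3ccccc3C2)nc2ccccc12` differs from compound 2 by a group of 4 heavy atoms (1 carbon, 3 nitrogen; no ring) in place of a group of 2 heavy atoms (1 carbon, 1 nitrogen; no ring), on a saturated chain carbon, two bonds along the chain from a nitrogen on an aromatic ring. Among the measured compounds shown here, the single measured step, a 2.5-fold lower number from compound 1 to compound 2 (0.40 log units; beyond the scatter), concerns a different change, so no measured step bears directly on this one. With nothing to guide the direction, compound 3 is expected to stay close to compound 2, a step of a 1.1-fold higher number from compound 2 to compound 3 (0.03 log units; within the scatter) within the scatter. The estimate for compound 3 is 9000 nM, with a range of 3000 nM to 30000 nM.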

Compound 3, half-maximal cytotoxic concentration: > 100000 nM
Compound 3 was reported as a limit; the forecaster's own chance of this, stated with the estimate: 10%; middle value at least 11-fold (1.04 log units) away from the limit.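

Compound 3 gives a limit of the assay and not a number: the limit of > 100000 nM in this assay, at which 1 of the 3 values shown sits.

At this chain position, the group with four heavy atoms in place of aminomethyl gives an at least 11-fold higher number from compound 2 to compound 3 (1.07 log units; beyond the scatter), so the read-out here can move strongly towards lower toxicity in this test, whereas the earlier step went the other way. The comparison with the hydroxy-bearing chain points the same way, with an at least 4.7-fold higher number from compound 1 to compound 3 (0.67 log units; beyond the scatter).

As far as these compounds go, how far the true value of compound 3 lies past the limit remains open. So does whether an amide, a carboxylic acid or a longer chain at this place would shift the number similarly.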